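This account rests on a few compounds, and the source may have more. Where it says the series, first, only, none or still open, it means among the compounds named here.

Measured so far:
compound 1 `CC(C)S(=O)(=O)CCC12CCC(c3nnc(-c4ccccc4C(F)(F)F)n3C)(CC1)CC2` — > 4000 nM
compound 2 `Cn1c(-c2ccccc2C(F)(F)F)nnc1C12CCC(CCS(C)(=O)=O)(CC1)CC2` — > 4000 nM

Both measured compounds share one core and differ only in the group on the sulfonyl sulfur. In an assay on CHO-K1 cells for inhibition of 11-beta-hydroxysteroid dehydrogenase type 2 (Mus musculus), read by scintillation proximity assay (on this read-out higher numbers stand for weaker inhibition and lower numbers for stronger inhibition), compound 1 gives > 4000 nM, which is a limit of the assay and not a number. In this assay compound 2 gives > 4000 nM, again a limit rather than a number. The step that the two limits leave unreadable from compound 1 to compound 2 is therefore unreadable, since both values sit at the limit of > 4000 nM in this assay, at which 2 of the 2 values shown sit.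

Compound 3 `CC(F)CCCC12CCC(c3nnc(-c4ccccc4C(F)(F)F)n3C)(CC1)CC2` has not yet been measured. It differs from compound 2 by 2-fluoropropyl in place of methylsulfonyl on a saturated chain carbon, two bonds along the chain from a saturated ring carbon. Among the compounds with values here, no measured step concerns a change of this kind, so nothing here sets a size or direction for the change in this assay. Because compound 2 sits at the limit of > 4000 nM in this assay, at which 2 of the 2 values shown sit, compound 3 is expected to remain weak, with the step that the limit leaves unreadable from compound 2 to compound 3 estimated as small. The estimate for compound 3 is 8000 nM, in a range from 2500 nM to 30000 nM, with a good chance that only a limit is reported again.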

Compound 3, half-maximal inhibitory concentration: > 4000 nM
Compound 3 ended at the assay's limit (the forecaster's own chance of this, stated with the estimate: 70%); the middle value is on the limit's open side.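

Within the data shown here, compound 1, compound 2 and compound 3 each give only a limit of the assay, not a number, in this assay, so no step among them can be read: the limit of > 4000 nM in this assay, at which 3 of the 3 values shown sit. The compounds shown leave open how strongly each one inhibits the enzyme, and whether any change to this side chain could give a readable number.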